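Notes on the oxadiazole to thiadiazole replacement

This account rests on a few compounds, and the source may have more. Where it says the series, first, only, none or still open, it means among the compounds named here.

Measured compounds, in a functional assay on MDA-MB-435S cells (Homo sapiens) for cytotoxicity, read by MTT assay, with a stated time of 72 h; a higher number here means a weaker inhibitor, a lower number a stronger inhibitor:
Compound 1 `O=c1cc(CSc2nc3ccccc3s2)oc2ccccc12` gives > 25000 nM, a limit of the assay and not a number.
Compound 2 `Cc1nnc(SCc2coc3ccc(Cl)cc3c2=O)o1` gives 3300 nM.
Compound 3 `Cc1cc(C)n2nc(SCc3nnc(SCc4cc(=O)c5ccccc5o4)o3)nc2n1` gives > 25000 nM, a limit of the assay and not a number.

Going by the values given here, compound 2 is the only compound of the three with a number in this assay; compound 1 and compound 3 stand at the limit of > 25000 nM in this assay, at which 2 of the 3 values shown sit. Among the compounds with values here, no two of the measured compounds differ in a single place, so no measured step is available to set the scale of a change at the sulfur.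

Compound 4 `Cc1nnc(SCc2coc3ccc(Cl)cc3c2=O)s1` has not been measured in this assay. It differs from compound 2 by 5-methyl-1,3,4-thiadiazol-2-yl in place of 5-methyl-1,3,4-oxadiazol-2-yl on a sulfur. The rest of the molecule, the halogenated core and the sulfur-linked chain carbon, is kept.

With no measured step of this kind in the series, the expectation rests on the smallness of the change: one ring hetero atom exchanged for another, with the same count of acceptors and no donor gained or lost. The step from compound 2 to compound 4 in this assay is estimated at a 1.2-fold lower number from compound 2 to compound 4 (0.07 log units; within the scatter), which is not beyond the usual scatter in either direction.

Compound 4 is therefore expected to give 2800 nM, with a range from 1000 nM to 8000 nM.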

Compound 4, half-maximal inhibitory concentration: 2200 nM
Beside the measured number, compound 4's estimate is 1.3-fold (0.10 log units) above it, within the range that was stated.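

In this assay, going by these compounds alone, the only measured step at this place is a 1.5-fold lower number from compound 2 to compound 4 (0.18 log units; within the scatter), with 5-methyl-1,3,4-thiadiazol-2-yl in place of 5-methyl-1,3,4-oxadiazol-2-yl on a sulfur whose other neighbours are: saturated chain carbon. The earlier compounds shown here offered no pair that differs in one place, and this pair now shows that, on the shared core, the two rings cannot be told apart in this read-out. Compound 1 and compound 3 remain limits of the assay and not numbers, and no step to either can be read: the limit of > 25000 nM in this assay, at which 2 of the 4 values shown sit.

Still open, as far as these compounds go, is how far this place accepts anything other than these two rings: an amine, a carboxylic acid or a longer chain on that sulfur would test it in a way that a swap of one ring hetero atom cannot. The compounds shown also leave open whether the same ring exchange would read the same way on a core without the chlorine, or with a methoxy group in its place.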